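Anilino variation on a shared tricyclic-sugar core: working notes

A few compounds are considered here, and "the series" means these few. Any claim that something is new, unique, unknown or untested is made for them only; others in the source may bear on it.

Measured so far:
- compound 1, `COc1ccccc1NC1=CC(=O)c2c(nc3n2[C@H]2OC[C@@H](O)[C@H]2OC3)C1=O`: in a functional assay on MGC-803 cells (Homo sapiens) for inhibition, read by sulforhodamine B assay (on this read-out lower numbers stand for stronger inhibition and higher numbers for weaker inhibition), compound 1 gives 1670 nM
- compound 2, `O=C1C=C(Nc2cccc(Cl)c2)C(=O)c2c1nc1n2[C@H]2OC[C@@H](O)[C@H]2OC1`: in this assay compound 2 gives 1770 nM

Compound 1 holds the lowest of the two numbers in this assay, but its gap to compound 2 lies within the scatter, so the two compounds read as equivalent. Compound 2 carries a 3-chlorophenyl on the amine nitrogen; compound 1 carries a 2-methoxyphenyl there.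

The next compound, compound 3, `O=C1C(Nc2cccc(F)c2)=CC(=O)c2c1nc1n2[C@H]2OC[C@@H](O)[C@H]2OC1`, differs from compound 1 in one place: 3-fluorophenyl in place of 2-methoxyphenyl on an amine nitrogen. Among the measured compounds shown here, no step between measured compounds covers this exchange. Because compound 2 with its 3-chlorophenyl gives 1770 nM, close to compound 1, the expected step of a 1.0-fold higher number from compound 1 to compound 3 (0.01 log units; within the scatter) is none beyond the scatter. Compound 3 is therefore estimated at 1700 nM in this assay, with a range from 800 nM to 3600 nM.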

Compound 3, half-maximal inhibitory concentration: 1470 nM
The estimate for compound 3 lay 1.2-fold (0.06 log units) above the measured number; measured number inside the range.
By their numbers in this assay, from the lowest: compounds 3, 1 and 2 (each within the scatter of the next).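

In this assay, among the compounds shown here, 3-fluorophenyl in place of 2-methoxyphenyl on the amine nitrogen gives a 1.1-fold lower number from compound 1 to compound 3 (0.06 log units; within the scatter) as the one step read at this position so far. This is a direct one-place comparison, and it shows that the hydrogen-bond acceptor counted on 2-methoxyphenyl is absent from 3-fluorophenyl with no change in the read-out beyond the scatter. Nothing available explains why the read-out holds across this exchange.

All the compounds shown carry a singly substituted phenyl on the amine nitrogen, so it remains open how a pyridyl, a benzyl or a cyclohexyl group would read there. On these data alone, it also remains open whether a carboxylic acid or a dimethylamino group on that phenyl would move the number beyond the scatter.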